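This account rests on a few compounds, and the source may have more. Where it says the series, first, only, none or still open, it means among the compounds named here.

Working notes on the series. Of the compounds shown here, three have been measured in an ADME assay on Vero cells (Chlorocebus sabaeus) for cytotoxicity, read by MTT assay, with a stated time of 48 h; a higher number here means a weaker inhibitor, a lower number a stronger inhibitor. Compound 1 `COc1ccccc1C(=O)OC1CCC(CN2CCN(c3cc(=O)c4cc(C(F)(F)F)cc([N+](=O)[O-])c4s3)CC2)CC1` is reported in this assay only as a limit of the assay, > 64 ug/mL, not as a number. Compound 2 `O=C(OC1CCC(CN2CCN(c3cc(=O)c4cc(C(F)(F)F)cc([N+](=O)[O-])c4s3)CC2)CC1)c1ccco1` likewise stands at a limit of the assay in this assay, > 64 ug/mL. For the measured compounds named here, compound 3 `CS(=O)(=O)NC1CCC(CN2CCN(c3cc(=O)c4cc(C(F)(F)F)cc([N+](=O)[O-])c4s3)CC2)CC1` is the one member with a read number in this assay, 48.5 ug/mL.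

The steps that end at that number are an at least 1.3-fold lower number from compound 1 to compound 3 (0.12 log units; that floor lies within the scatter) and an at least 1.3-fold lower number from compound 2 to compound 3 (0.12 log units; that floor lies within the scatter); each floor lies within the scatter. The pair compound 1 to compound 2 gives a step that the two limits leave unreadable from compound 1 to compound 2.

Compound 4 `O=C(OC1CCC(CN2CCN(c3cc(=O)c4cc(C(F)(F)F)cc([N+](=O)[O-])c4s3)CC2)CC1)c1ccc(F)cc1` differs from compound 3 in one place: ((4-fluorophenyl)carbonyl)oxy in place of methanesulfonamido on a saturated ring carbon. It thereby carries a carbonyloxy group on that saturated ring carbon, as compound 1 and compound 2 do.

Going by the values given here, the steps that bear on this change are those from compound 1 and from compound 2 to compound 3, read backwards; both floors sit within the scatter, and both starting values rest on (the limit of > 64 ug/mL in this assay, at which 2 of the 3 values shown sit). A step towards a higher number, likely reaching the limit again, is therefore expected, and the step expected from compound 3 is a 1.5-fold higher number from compound 3 to compound 4 (0.19 log units; within the scatter). For compound 4 the estimate in this assay is 75 ug/mL, with a range from 40 ug/mL to 160 ug/mL.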

Compound 4, half-maximal inhibitory concentration: > 64 ug/mL
Compound 4 was reported as a limit; the forecaster's own chance of this, stated with the estimate: 65%; the middle value does not contradict the limit.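

In this assay, ((4-fluorophenyl)carbonyl)oxy in place of methanesulfonamido on the saturated ring carbon gives an at least 1.3-fold higher number from compound 3 to compound 4 (0.12 log units; that floor lies within the scatter); this adds a third carbonyloxy example to the comparison with compound 3, but it still shows only a floor, not a size. Compound 1, compound 2 and compound 4, which carry 2-methoxyphenyl, furan-2-yl and 4-fluorophenyl on the carbonyl carbon, all stand at a limit rather than a number: the limit of > 64 ug/mL in this assay, at which 3 of the 4 values shown sit. The steps among these three compounds cannot be read, so the change of group on the carbonyl carbon has no measurable size here, and the series offers no order among them.

As far as these compounds go, whether the exchange of methanesulfonamido for a carbonyloxy group moves the result beyond the scatter remains open, as does the true position of the three compounds reported only as limits. Also open, from the compounds shown here alone, is how a primary amine, a carboxylic acid or an acetamido group on the same saturated ring carbon would read in this assay.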